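The compounds below may be only part of what the source reports. "The series", "measured", "known", "first", "only" and "open" are said of these compounds alone.

Measured compounds:
compound 1 `Cc1nc(N)sc1CCCN/C(N)=N/C(=O)N[C@H](C)c1ccccc1` — 0.95
compound 2 `Cc1nc(N)sc1CCCN/C(N)=N/C(=O)NC(C)c1ccc(Br)cc1` — 0.87
compound 3 `Cc1nc(N)sc1CCCN/C(N)=N/C(=S)N[C@@H](C)c1ccccc1` — 0.65

The read-out throughout is a functional assay on Right cardiac atrium for agonist activity at histamine H2 receptor (Cavia porcellus), with a stated time of 30 min, in the presence of a further agent that is not named here; a higher number here means a larger maximal response, a lower number a smaller maximal response. In this assay compound 1 gives 0.95, close to the reference agonist. Compound 2 gives 0.87, which lies within the usual scatter of the number for compound 1, so the two cannot be ordered. Compound 3 gives 0.65; that number lies beyond the scatter below compound 1, and is the only clear gap among the three.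

The next compound is compound 4 `CCCCCCNC(=O)/N=C(\N)NCCCc1sc(N)nc1C`. It differs from compound 1 in one place: hexyl in place of 1-phenylethyl on an amide-type nitrogen. Among the measured compounds shown here, no measured pair shows this kind of exchange, so no step can be read directly from the data; the only structural changes with numbers attached are the one from compound 1 to compound 2 and the one from compound 1 to compound 3, neither of which touches the same group.

With the evidence at hand, the step from compound 1 to compound 4 is estimated at a number 0.10 lower from compound 1 to compound 4 (within the scatter), a small fall, near the edge of the scatter. Compound 4 is therefore expected to give about 0.85 in this assay, with a range from 0.65 to 1.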

Compound 4, intrinsic activity: the largest response reached, as a fraction of the reference agonist's: 0.95
The estimate for compound 4 lay 0.10 below the measured number; low and high end bracket the measured number.
By their numbers in this assay, from the lowest: compound 3; then compounds 2, 1 and 4 (each within the scatter of the next).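

In this assay, hexyl in place of 1-phenylethyl on an amide-type nitrogen brings no change at the digits printed from compound 1 to compound 4 (within the scatter). In this pair, the maximal response therefore does not depend on the six-membered aromatic ring or the defined stereocentre of 1-phenylethyl: an open chain with no ring serves as well at this position. No measurement at hand bears on why the response holds across this exchange.

Still open, on these data alone, is whether a shorter chain such as butyl, a longer chain such as octyl, or a hexyl chain ending in an amine or a carboxylic acid would keep the response at this level. Also open, as far as these compounds go, is whether the same exchange would read the same way on compound 3, which gives a clearly smaller maximal response.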